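The source may hold more compounds than are shown below. What is called first, only, known or untested is meant among the compounds shown, and "the series" means these compounds.

Working notes on the series. In a functional assay on HepG2 cells (Homo sapiens) for cytotoxicity, read by MTT assay, with a stated time of 72 h (on this read-out higher numbers stand for weaker inhibition and lower numbers for stronger inhibition), compound 3 `Cc1cc(=O)n(-c2ccccc2OC(F)(F)F)nc1C(=O)Nc1ccc(Oc2ncnc3c2ccn3C)cc1` reaches only the assay limit > 60000 nM, not a number. Compound 1 `Cn1ccc2c(Oc3ccc(NC(=O)c4nn(-c5ccc(Cl)c(F)c5)ccc4=O)cc3)ccnc21` likewise sits at the limit > 60000 nM. Compound 2 `Cc1cc(=O)n(-c2ccccc2OC(F)(F)F)nc1C(=O)Nc1ccc(Oc2ncnc3[nH]ccc23)cc1` gives a number, 22800 nM. Among the measured compounds shown here, the one measured step, an at least 2.6-fold higher number from compound 2 to compound 3 (0.42 log units; beyond the scatter), runs toward weaker inhibition, and the limit of > 60000 nM in this assay, at which 2 of the 3 values shown sit, shows how much of the set rests at that ceiling. Compound 4 `Cc1ccc(-n2nc(C(=O)Nc3ccc(Oc4ncnc5c4ccn5C)cc3)c(C)cc2=O)cc1` differs from compound 3 by 4-methylphenyl in place of 2-(trifluoromethoxy)phenyl on an aromatic nitrogen. For the measured compounds named here, no measured step exchanges the aryl group on that aromatic nitrogen, so the change itself carries no precedent here. Given that compound 3 stands at > 60000 nM, compound 4 is expected to remain near the ceiling, a step of an at least 1.2-fold lower number from compound 3 to compound 4 (0.07 log units; that floor lies within the scatter) within the scatter. The estimate for compound 4 is 50000 nM, range 15000 nM to 100000 nM.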

Compound 4, half-maximal inhibitory concentration: 33800 nM
Compound 4: the middle estimate sits 1.5-fold (0.17 log units) above what was measured; the measured number falls inside the stated range.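

Among the compounds shown here, the exchange of 2-(trifluoromethoxy)phenyl for 4-methylphenyl on the aromatic nitrogen is the first reading at this position, and in this assay it gives an at least 1.7-fold lower number from compound 3 to compound 4 (0.24 log units; that floor lies within the scatter). Compound 4 has a number on this core, but the size of the step stays unknown because only its floor can be read: the limit of > 60000 nM in this assay, at which 2 of the 4 values shown sit.

Open, as far as these compounds go, is whether the change comes from losing the trifluoromethoxy group or from gaining the methyl group. Also open, from the compounds shown here alone, is what an amine or a carboxylic acid on this phenyl ring would give.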